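A Benzamide in Place of an Acetamide

The source may report more compounds than this note shows. Statements on the series, on what has been measured and on what is new or still open speak of the compounds shown alone.

In an assay on isolated protein for inhibition of Rho-associated protein kinase 1 (Homo sapiens), read by scintillation counting, radiometric assay and 33P incorporation, with a stated time of 40 min, in the presence of a further agent that is not named here (a lower number here means a stronger inhibitor, a higher number a weaker inhibitor), compound 2 `CC(=O)Nc1cccc(NC(=O)COc2ccc3c(=O)ccoc3c2)c1` gives 2500 nM, the only number shown here. Compound 1 `CN(C)c1ccc(C(=O)Nc2cccc(NC(=O)COc3ccc4c(c3)CCC(=O)N4)c2)cc1` gives only a limit, > 10000 nM. So compound 2 stands alone with a measured figure, while the limit of > 10000 nM in this assay, at which 1 of the 2 values shown sits, marks the other. Compound 3 `CCCc1ccc(C(=O)Nc2cccc(NC(=O)COc3ccc4c(=O)ccoc4c3)c2)cc1` carries 4-propylphenyl in place of methyl on a carbonyl carbon, acetyl becoming (4-propylphenyl)carbonyl. Going by the values given here, no measured step covers such a change, so the expectation rests on compound 2 alone. Compound 3 is expected to land near 3000 nM, within 800 nM to 15000 nM. The step this implies, a 1.2-fold higher number from compound 2 to compound 3 (0.08 log units; within the scatter), is expected to stay within the usual scatter, in no clear direction.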

Compound 3, half-maximal inhibitory concentration: 143 nM
Compound 3: middle estimate off by 21-fold (1.32 log units), on the high side; measured number below the stated range.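

Going by these compounds alone, on the carbonyl carbon whose other neighbour is the amide-type nitrogen, the change from methyl to 4-propylphenyl brings a 17-fold lower number from compound 2 to compound 3 (1.24 log units; beyond the scatter) in this assay and is the first measured step. It shows that this place accepts a group far larger than methyl, and that activity there responds strongly to the change. Nothing among the data shown explains the gain.

The compounds shown do not separate the contribution of the ring from that of the propyl chain. From the compounds shown here alone, it remains open how an unsubstituted phenyl, or a phenyl carrying a methoxy group or a carboxylic acid in place of propyl, would compare.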